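The source may hold more compounds than are shown below. What is called first, only, known or untested is meant among the compounds shown, and "the series" means these compounds.

Compound 2 `COc1ccc(F)cc1CNCCCNc1ccnc2cc(Oc3ccccc3)ccc12` gives 9.28 in a physicochemical assay for acid dissociation. Within the data shown here, compound 1 `COc1cccc(Oc2ccc3c(NCCCNCc4cc(F)ccc4OC)ccnc3c2)c1` gives 9.28 in this assay, and the step of no change at the digits printed from compound 1 to compound 2 (within the scatter) is the only measured step, so compound 2 stands level with its one neighbour. Compound 3 `COc1ccc(F)cc1CNCCCNc1ccnc2cc(-c3cccc4ccccc34)ccc12` has not yet been measured in this assay. The change from compound 2 to compound 3 is naphthalen-1-yl in place of phenoxy on an aromatic carbon. Among the measured compounds shown here, the one measured step bears on it only loosely: it swapped a group on an aromatic carbon away from both amine nitrogens and left this assay unmoved, whereas here a larger replacement is made on the core, again with both amine nitrogens unchanged. For the measured compounds named here, with no measured step that moves this assay, the step of a number 0.02 log units higher from compound 2 to compound 3 (within the scatter) is expected to stay within the scatter. Compound 3 is therefore estimated at 9.3, in the range 9 to 9.6.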

Compound 3, acid dissociation constant: 9.47
Beside the measured number, compound 3's estimate is 0.17 log units below it, within the range that was stated.
By their numbers in this assay, from the lowest: compounds 1, 2 and 3 (each within the scatter of the next).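

In this assay, the aromatic carbon carrying the group now takes an all-carbon naphthalen-1-yl in place of phenoxy, giving a number 0.19 log units higher from compound 2 to compound 3 (within the scatter); this swap removes the oxygen and adds a second six-membered aromatic ring. The replacement of 3-methoxyphenoxy gives a number 0.19 log units higher from compound 1 to compound 3 (within the scatter), so a change of the whole group at this place, not only the loss of methoxy seen earlier, stays inside the scatter of this assay in these compounds. No supporting evidence bears on these steps.

As far as these compounds go, what a carboxylic acid or a piperidine at this position would do in this assay stays open. So does the effect of a longer chain linking the two amine nitrogens, since compound 1, compound 2 and compound 3 all share the same chain.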